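Arylidene oxindoles: cytotoxicity notes on compound 1 and compound 3

This account rests on a few compounds, and the source may have more. Where it says the series, first, only, none or still open, it means among the compounds named here.

Compound 1 `O=C1/C(=C\c2c(Cl)cccc2Cl)c2ccccc2N1c1c(Cl)cccc1Cl` carries the same core as compound 2 `O=C1/C(=C\c2cccc(Oc3ccccc3)c2)c2ccccc2N1c1c(Cl)cccc1Cl`, with a different group on the double-bonded chain carbon. In a functional assay on HuTu80 cells (Homo sapiens) for cytotoxicity, read by MTT assay, with a stated time of 72 h (a lower number here means that less compound is needed, a higher number that more compound is needed for the effect), compound 1 gives 100 ug/mL, the highest of the two numbers measured. The nearest neighbour, compound 2, gives 10 ug/mL in this assay; the gap between these two values lies beyond the scatter, so compound 1 stands as the weaker of the pair in this pair.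

Compound 3 `CN(C)c1ccc(/C=C2\C(=O)N(c3c(Cl)cccc3Cl)c3ccccc32)cc1` differs from compound 1 in one place: 4-(dimethylamino)phenyl in place of 2,6-dichlorophenyl on a double-bonded chain carbon bound to a double-bonded ring carbon. Among the measured compounds shown here, no measured step for this exact exchange exists, so the expectation rests only on the two values shown. Since compound 2 moves to a lower number than compound 1 once the 2,6-dichlorophenyl on the double-bonded chain carbon is exchanged for another aryl group, a step in the same direction is expected for compound 3, of moderate size and beyond the scatter: an estimated 3.3-fold lower number from compound 1 to compound 3 (0.52 log units; beyond the scatter). Compound 3 is therefore expected to give about 30 ug/mL in this assay, within a range of 8 ug/mL to 100 ug/mL.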

Compound 3, concentration for half-maximal effect: < 1 ug/mL
Compound 3: no number, only a limit (the forecaster's own chance of this, stated with the estimate: 15%); middle value at least 30-fold (1.47 log units) from the limit.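

In this assay, 4-(dimethylamino)phenyl in place of 2,6-dichlorophenyl on a double-bonded chain carbon bound to a double-bonded ring carbon gives an at least 100-fold lower number from compound 1 to compound 3 (2.00 log units; beyond the scatter), a large step. Compound 3 is recorded only as a limit of the assay and not as a number: the limit of < 1 ug/mL in this assay, at which 1 of the 3 values shown sits. Compound 2 had already shown that the read-out responds to the aryl group at this place, and compound 3 now shows that this response can reach the assay's limit with a single exchange, one that keeps the six-membered aromatic ring, removes both chlorine atoms and brings in a nitrogen and a hydrogen-bond acceptor.

On these data alone, the full size of the step stays open, as does whether it follows from the loss of the chlorine atoms or from the entry of the dimethylamino group. A comparison of compound 1 and compound 3 with a primary amine or a methoxy group on the same phenyl ring, in place of the dimethylamino group, would bear on that second question.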